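Swapping a Side Chain for a Chlorinated Ring

The source may report more compounds than this note shows. Statements on the series, on what has been measured and on what is new or still open speak of the compounds shown alone.

Of the compounds shown here, two that share one core have been measured. Compound 1 `[N-]=[N+]=NCC(O)Cn1c(=O)n(C2OC(CO)[C@@H](O)[C@H]2O)c2nc(N)nc(O)c21` reaches 91% in a functional assay on the whole organism (B cells) with Mus musculus as the target (on this read-out higher numbers stand for larger maximal responses and lower numbers for smaller maximal responses), the highest of the two numbers available. For the measured compounds named here, compound 2 `C=CCn1c(=O)n(C2CCC(CO)C2)c2nc(N)nc(O)c21` differs from compound 1 in several places, so no single step between the two can be traced. In this assay compound 2 gives 26%, and the gap between the two numbers is beyond the usual scatter.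

Compound 3 `Nc1nc(O)c2c(n1)n(C1OC(CO)[C@@H](O)[C@H]1O)c(=O)n2Cc1ccc(Cl)cc1` has not yet been measured. Relative to compound 1 it carries 4-chlorophenyl in place of 2-azido-1-hydroxyethyl on a saturated chain carbon bound to an aromatic nitrogen. Because compound 1 stands at 91%, there is room mostly downward, and with no measured step of this kind to lean on, a moderate loss of maximal response is expected from compound 1 to compound 3, shown as a number 26 percentage points lower from compound 1 to compound 3 (beyond the scatter). Compound 3 is therefore estimated at 65% in this assay, within a range from 30% to 95%.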

Compound 3, largest response reached (reported as maximal response), in percent of the reference or control that the assay uses: 15%
Estimate against measurement, compound 3: 50 percentage points above; the whole stated range lies above it.
By their numbers in this assay, from the lowest: compound 3; then compound 2; then compound 1.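

For the compounds shown here, compound 3 gives the first traceable step at this position, on a saturated chain carbon bound to an aromatic nitrogen: in this assay, changing 3-azido-2-hydroxypropyl to 4-chlorobenzyl gives a number 76 percentage points lower from compound 1 to compound 3 (beyond the scatter) while the rest of the molecule stays the same. The maximal response therefore depends strongly on which group sits here, at least for this pair. Nothing shown explains the size of this step.

The change swaps a chain for an aromatic ring and also removes the azide and hydroxyl while adding chlorine, so it remains open which of these differences accounts for the step. A plain benzyl group or a 3-amino-2-hydroxypropyl chain at this place would help separate those differences.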